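From 4-nitrophenyl to 3-bromophenyl in a cytotoxic series

The source may report more compounds than this note shows. Statements on the series, on what has been measured and on what is new or still open speak of the compounds shown alone.

In a functional assay on MCF7 cells (Homo sapiens) for cytotoxicity, read by MTT assay, with a stated time of 24 h (on this read-out lower numbers stand for stronger inhibition and higher numbers for weaker inhibition), compound 3 (`C/C(=N\NC(=O)/C(C#N)=C/c1ccc([N+](=O)[O-])cc1)c1c(O)c2ccc(O)cc2oc1=O`) gives 8200 nM. This is level with compound 1 (`COc1ccc(/C=C(\C#N)C(=O)N/N=C(\C)c2c(O)c3ccc(O)cc3oc2=O)cc1`) at 8940 nM, whereas compound 2 (`C/C(=N\NC(=O)/C(C#N)=C/c1ccc(N(C)C)cc1)c1c(O)c2ccc(O)cc2oc1=O`) gives 3420 nM, the strongest inhibition of the three. Compound 4 (`C/C(=N\NC(=O)/C(C#N)=C/c1cccc(Br)c1)c1c(O)c2ccc(O)cc2oc1=O`) awaits measurement in this assay. The change is 3-bromophenyl in place of 4-nitrophenyl on a double-bonded chain carbon bound to a double-bonded chain carbon.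

The measured steps each exchange a single group on an aromatic carbon. There is a 1.1-fold lower number from compound 1 to compound 3 (0.04 log units; within the scatter) for nitro in place of methoxy, and this stays within the scatter. The other two are modest: a 2.6-fold lower number from compound 1 to compound 2 (0.42 log units; beyond the scatter) and a 2.4-fold higher number from compound 2 to compound 3 (0.38 log units; beyond the scatter). Among the compounds with values here, none of the measured compounds carries bromine, so these steps offer only a guide to size. With the largest of them being the modest 2.6-fold lower number from compound 1 to compound 2 (0.42 log units; beyond the scatter), no step beyond the scatter is expected, in either direction. The expected step is a 1.3-fold lower number from compound 3 to compound 4 (0.10 log units; within the scatter). For compound 4 the estimated value is 6500 nM, with an expected range from 2800 nM to 14000 nM.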

Compound 4, half-maximal inhibitory concentration: 19600 nM
Compound 4: the middle estimate sits 3.0-fold (0.48 log units) below what was measured; the measured number lies above the stated range.
By their numbers in this assay, from the lowest: compound 2; then compounds 3 and 1 (each within the scatter of the next); then compound 4.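

Against 4-nitrophenyl, 4-methoxyphenyl and 4-(dimethylamino)phenyl alike, 3-bromophenyl on this double-bonded chain carbon gives weaker inhibition in this assay, with a 2.4-fold higher number from compound 3 to compound 4 (0.38 log units; beyond the scatter), a 2.2-fold higher number from compound 1 to compound 4 (0.34 log units; beyond the scatter) and, as the widest gap in the set, a 5.7-fold higher number from compound 2 to compound 4 (0.76 log units; beyond the scatter). Compound 4 is therefore the weakest of the four, showing that the number at this position can rise past the level shared by compound 1 and compound 3, and not only fall as it does for compound 2. No measurement shown accounts for this shift.

The compounds shown leave open whether the higher number goes with the bromine or with its place on the ring, a question that 4-bromophenyl at this position would address. Also open, on these data alone, is how 3-methoxyphenyl or 3-nitrophenyl would compare with 3-bromophenyl here.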